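The source may report more compounds than this note shows. Statements on the series, on what has been measured and on what is new or still open speak of the compounds shown alone.

In a functional assay on the whole organism with Mus musculus as the target (on this read-out lower numbers stand for an effect already at smaller amounts and higher numbers for an effect only at larger amounts of compound), compound 1 `Cc1c(C)c2c(c(C)c1N)CC(C)(COCc1ccccc1)O2` gives 18.6 mg/kg and compound 2 `Cc1c(C)c2c(c(C)c1N)CC(C)(CCN(C)C)O2` gives 19 mg/kg, two values within the usual scatter of each other. Compound 3 `CCOC(=O)Nc1c(C)c(C)c2c(c1C)CC(C)(C)O2` reads > 100 mg/kg, which is a limit of the assay and not a number. Compound 4 `Cc1c(C)c2c(c(C)c1Nc1ccccc1)CC(C)(C)O2` differs from compound 3 in one place: phenyl in place of ethoxycarbonyl on a nitrogen on an aromatic ring. This puts phenyl in place of ethoxycarbonyl on a nitrogen on an aromatic ring. Within the data shown here, no measured step covers this change. Among the measured compounds shown here, the only guide is that compound 1, at 18.6 mg/kg, has no ethoxycarbonyl on that nitrogen, though it also differs elsewhere. The expected at least 2.5-fold lower number from compound 3 to compound 4 (0.39 log units; beyond the scatter) points towards smaller doses. For compound 4 the estimated value is 40 mg/kg, with an expected range of 15 mg/kg to 100 mg/kg.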

Compound 4, dose for 50% inhibition: > 50 mg/kg
Compound 4: a limit, no number; the forecaster's own chance of this, stated with the estimate: 30%; middle value at least 1.2-fold (0.09 log units) away from the limit.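

Among these compounds, compound 3 and compound 4 both read as limits, not numbers, in this assay, and no step between them can be read. The compounds shown leave open what phenyl in place of ethoxycarbonyl on a nitrogen on an aromatic ring does to the dose.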